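The source may report more compounds than this note shows. Statements on the series, on what has been measured and on what is new or still open speak of the compounds shown alone.

Compound 1 `CC1=C(C(N)=O)C(c2ccsc2)NC(=O)N1` gives 2% in an assay on membranes from CHO cells for displacement of a labelled ligand from adenosine receptor A1 (Homo sapiens), read by scintillation counting, with a stated time of 60 min, tested at 1 uM (on this read-out higher numbers stand for more inhibition at the one concentration tested (going by the name of the read-out) and lower numbers for less inhibition), and stands lowest of the two measured numbers; compound 2 `CC1=C(c2ncc(C)o2)C(c2ccsc2)NC(=O)N1` gives 34%. Within the data shown here, the one recorded step, a number 32 percentage points higher from compound 1 to compound 2 (beyond the scatter), is large and follows the replacement of carbamoyl by 5-methyl-1,3-oxazol-2-yl on a double-bonded ring carbon. Compound 3 `CCC(CC)OC(=O)C1=C(C)NC(=O)NC1c1ccsc1` differs from compound 1 as follows: (pentan-3-yl)oxy in place of amino on a carbonyl carbon. Among the measured compounds shown here, no measured step touches the carbonyl carbon in this way, so that step bears only loosely on it. Compound 3 is therefore expected to sit near 15%, between 0% and 45%, which would mean an estimated step of a number 13 percentage points higher from compound 1 to compound 3 (beyond the scatter).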

Compound 3, a percentage reported as inhibition, at one concentration (the size of the read-out at that concentration, not a potency): 22%
Beside the measured number, compound 3's estimate is 7 percentage points below it; the range from low to high includes it.
By their numbers in this assay, from the lowest: compound 1; then compound 3; then compound 2.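

With the carbonyl carbon kept, exchanging amino for (pentan-3-yl)oxy gives a number 20 percentage points higher from compound 1 to compound 3 (beyond the scatter) in this assay, so a gain over compound 1 at this position does not require replacing the whole carbamoyl group, as in compound 2. The change removes the amino hydrogen-bond donor and adds a branched chain, and the data do not separate these two differences. No measurement available here explains the step. Open, from the compounds shown here alone, is whether a methoxy group or a longer chain on the same carbonyl carbon would follow compound 3. Going by these compounds, a carboxylic acid or an N-methyl amide there is equally open.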